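The compounds below may be only part of what the source reports. "The series", "measured", "known", "first", "only" and "open" are said of these compounds alone.

Values in a functional assay on A-375 cells (Homo sapiens) for activation, with a stated time of 3 days; a higher number here means that more compound is needed for the effect, a lower number that less compound is needed:
- compound 1 `O=C(Nc1ccc(-c2cscn2)cc1)C1CCCN(Cc2ccc(F)c(F)c2)C1`: 1240 nM
- compound 2 `O=C(Nc1ccc(-c2ccccc2)cc1)C1CCCN(Cc2ccc(F)c(F)c2)C1`: 5000 nM
- compound 3 `O=C(Nc1ccc(-c2ccoc2)cc1)C1CCCN(Cc2ccc(F)c(F)c2)C1`: 3000 nM

Compound 3 lies on the high side of this short series, with a 2.4-fold higher number from compound 1 to compound 3 (0.38 log units; beyond the scatter), while a 1.7-fold lower number from compound 2 to compound 3 (0.22 log units; within the scatter) leaves no real separation. Compound 4 `O=C(Nc1ccc(-c2ccco2)cc1)C1CCCN(Cc2ccc(F)c(F)c2)C1` carries furan-2-yl in place of furan-3-yl on an aromatic carbon. Going by the values given here, no measured step exchanges one furan attachment for the other. The nearest evidence is ring exchange at the same place, where the largest measured step is the modest 4.0-fold higher number from compound 1 to compound 2 (0.61 log units; beyond the scatter). A change within the scatter is therefore expected in this assay, with no firm direction. The expected step is a 1.2-fold lower number from compound 3 to compound 4 (0.08 log units; within the scatter). Compound 4 is estimated at 2500 nM, with an expected range of 1000 nM to 6000 nM.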

Compound 4, half-maximal effective concentration: 2200 nM
The estimate for compound 4 lay 1.1-fold (0.06 log units) above the measured number; low and high end bracket the measured number.
By their numbers in this assay, from the lowest: compounds 1, 4, 3 and 2 (each within the scatter of the next, the first and the last beyond it).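

In this assay the furan attachment point makes no real difference at this position (a 1.4-fold lower number from compound 3 to compound 4 (0.13 log units; within the scatter)). Furan-2-yl separates from phenyl (a 2.3-fold lower number from compound 2 to compound 4 (0.36 log units; beyond the scatter)), whereas it does not separate from 1,3-thiazol-4-yl (a 1.8-fold higher number from compound 1 to compound 4 (0.25 log units; within the scatter)). No measurement available here explains these numbers.

Still open, from the compounds shown here alone, is whether a ring bearing more than one hetero atom other than 1,3-thiazol-4-yl, such as a pyridine or an oxazole, would give a lower number here. Also open, going by these compounds, is how an amine or a carboxylic acid would fare at this position.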